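Iodine for Chlorine: One Swap Tested on a Second Core

The source may report more compounds than this note shows. Statements on the series, on what has been measured and on what is new or still open speak of the compounds shown alone.

Of the compounds shown here, three have been measured in an ADME assay on RAW264.7 cells (Mus musculus) for cytotoxicity, read by MTT assay, with a stated time of 24 h; on this read-out lower numbers stand for higher toxicity in this test and higher numbers for lower toxicity in this test. Compound 1 `O=c1oc2ccc(Br)cc2c(=O)n1-c1ccc(I)cc1F` gives 7900 nM, compound 2 `O=c1oc2ccc(Br)cc2c(=O)n1-c1ccc(Cl)cc1F` gives 7500 nM, and compound 3 `O=C(Nc1ccc(F)cc1F)c1cc(Cl)ccc1O` gives 14600 nM. Compounds 1 and 2 share a core and differ at one point: iodo in place of chloro on an aromatic carbon That change gave a 1.1-fold higher number from compound 2 to compound 1 (0.02 log units; within the scatter). How the core of compound 3 differs from the core of compound 2 is not broken down here. Compound 4 `O=C(Nc1ccc(F)cc1F)c1cc(I)ccc1O` is not yet measured and differs from compound 3 as follows: iodo in place of chloro on an aromatic carbon This is the same kind of change as from compound 2 to compound 1, but the surroundings differ: here the carbon is meta to a large group and para to a hydroxy group, whereas before it was meta to a fluoro group and para to a large group. The expected step is a 1.0-fold higher number from compound 3 to compound 4 (0.01 log units; within the scatter), resting on the measured 1.1-fold higher number from compound 2 to compound 1 (0.02 log units; within the scatter). Compound 4 is therefore estimated at 15000 nM, likely between 7500 nM and 30000 nM.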

Compound 4, half-maximal cytotoxic concentration: 13700 nM
Compound 4: middle estimate off by 1.1-fold (0.04 log units), on the high side; measured number inside the range.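

On the core of compound 3, iodo in place of chloro gives a 1.1-fold lower number from compound 3 to compound 4 (0.03 log units; within the scatter) in this assay. Set beside the earlier step, the swap behaves alike on both cores, with neither step standing out from the scatter: the same change on two cores in this assay, a 1.1-fold higher number (0.02 log units; within the scatter) from compound 2 to compound 1 and a 1.1-fold lower number (0.03 log units; within the scatter) from compound 3 to compound 4, 1.1-fold (0.05 log units) apart, within the scatter of two such steps. This shows that, in this test, the exchange of these two halogens made no readable difference on either core, but it does not show that the same would hold on a third core or in any other test.

The compounds shown leave open what a group other than these halogens would do at this place on the ring. An amine, a nitrile or a carboxylic acid in place of the iodo could give a different result, and nothing here tells either way.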